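Moving the Halogen on the Anilino Ring

The source may hold more compounds than are shown below. What is called first, only, known or untested is meant among the compounds shown, and "the series" means these compounds.

Measured so far:
- Compound 1, `CCOC(=O)C1=C(Nc2ccc(Br)cc2)S/C(=C\c2ccc[nH]2)C1=O`: in a functional assay on JAR cells (Homo sapiens) for inhibition, read by MTT assay, with a stated time of 72 h, tested at 10 uM (on this read-out higher numbers stand for more inhibition at the one concentration tested (going by the name of the read-out) and lower numbers for less inhibition), compound 1 gives 41.5%.
- Compound 2, `CCOC(=O)C1=C(Nc2ccccc2Br)S/C(=C\c2ccc[nH]2)C1=O`: in this assay compound 2 gives 62.7%.

The two compounds share one core and differ only in where the bromine sits on the phenyl ring attached to the amine nitrogen. For the measured compounds named here, the single measured step, a number 21.2 percentage points higher from compound 1 to compound 2 (beyond the scatter), shows that shifting that halogen alone moved the read-out beyond the scatter. Compound 2 therefore stands highest of the two numbers, with compound 1 the nearer and lower one.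

Compound 3, `CCOC(=O)C1=C(Nc2cccc(F)c2)S/C(=C\c2ccc[nH]2)C1=O`, is the next step: 3-fluorophenyl in place of 2-bromophenyl on an amine nitrogen. Going by the values given here, no measured step covers fluorine in place of bromine, and none covers a 3-substituted phenyl, so the change is only partly informed. Because a number 21.2 percentage points higher from compound 1 to compound 2 (beyond the scatter) was beyond the scatter, a step of comparable size in this assay is plausible; compound 1, which also lacks a 2-bromophenyl, gives 41.5%, which points downward. Compound 3 is expected to give 48%, within 25% to 70%. The expected step is estimated as a number 14.7 percentage points lower from compound 2 to compound 3 (beyond the scatter), a decrease.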

Compound 3, a percentage reported as inhibition, at one concentration (the size of the read-out at that concentration, not a potency): 45.4%
Compound 3: middle estimate off by 2.6 percentage points, on the high side; measured number inside the range.
By their numbers in this assay, from the lowest: compounds 1 and 3 (each within the scatter of the next); then compound 2.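

For the compounds shown here, at this position the high number so far belongs to 2-bromophenyl alone: replacing it with 3-fluorophenyl gives a number 17.3 percentage points lower from compound 2 to compound 3 (beyond the scatter) in this assay. Setting 3-fluorophenyl against 4-bromophenyl gives a number 3.9 percentage points higher from compound 1 to compound 3 (within the scatter), so these two groups cannot be told apart on this read-out, even though they differ in both the halogen and its place on the ring, and only 2-bromophenyl stands clear of the other two. Nothing measured here explains why the read-out responds this way at the amine nitrogen.

Compound 3 changes the halogen and its place on the ring in a single move, so the compounds shown cannot separate what the bromine itself contributes from what its place contributes. They also leave open how this ring would read with no halogen at all, for example with a methoxy group or an amine in the halogen's stead.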